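The compounds below may be only part of what the source reports. "The series", "measured", "known", "first", "only" and "open" are said of these compounds alone.

Compound 1 `C[C@@H](Cn1ccc(-c2ccc(C#N)c(Cl)c2)n1)NC(=O)c1ccccc1`: in a functional assay on VCaP cells (Homo sapiens) for antiproliferative activity, read by CCK-8 assay, with a stated time of 6 days (on this read-out lower numbers stand for stronger inhibition and higher numbers for weaker inhibition), compound 1 gives "not determined" (no result reported).
Compound 2 `CC(Cn1ccc(-c2ccc(C#N)c(Cl)c2)n1)C(=O)Nc1cc[nH]n1`: in this assay compound 2 reaches only the assay limit, > 30000 nM.
Compound 3 `CC(=O)c1cccc(NC(=O)C(C)Cn2ccc(-c3ccc(C#N)c(Cl)c3)n2)c1`: in this assay compound 3 gives 2980 nM.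

Compound 1 therefore has no number of its own in this assay, and of the other two values one is only a limit (the limit of > 30000 nM in this assay, at which 1 of the 3 values shown sits). Among the compounds with values here, the single measured step, an at least 10-fold lower number from compound 2 to compound 3 (1.00 log units; beyond the scatter), concerns a different position and so gives no direct guide. The change leading to compound 4 `Cc1ccnc(N[C@@H](C)Cn2ccc(-c3ccc(C#N)c(Cl)c3)n2)n1` is 4-methylpyrimidin-2-yl in place of benzoyl on an amine nitrogen. With no anchor for compound 1, the expectation for compound 4 can only lean on compound 3, whose value is 2980 nM. Compound 4 is estimated to give about 1500 nM, with a likely range from 300 nM to 10000 nM.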

Compound 4, half-maximal inhibitory concentration: 850 nM
Beside the measured number, compound 4's estimate is 1.8-fold (0.25 log units) above it; the measured number falls inside the stated range.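

Within the data shown here, compound 1 has no reported result, and no step from it to compound 4 can be read. Nothing shown here accounts for the value of compound 4. From the compounds shown here alone, how 4-methylpyrimidin-2-yl compares with benzoyl on the amine nitrogen in this assay stays open.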